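The compounds below may be only part of what the source reports. "The series", "measured", "known", "first", "only" and "open" are said of these compounds alone.

In a functional assay on SW982 cells (Homo sapiens) for inhibition, read by MTT assay, with a stated time of 72 h (on this read-out lower numbers stand for stronger inhibition and higher numbers for weaker inhibition), compound 1 `COc1cc(OC)c(OC)cc1/C=C/C(=O)c1ccc(-c2c[nH]cn2)cc1` gives > 150000 nM, which is a limit of the assay and not a number. Compound 2 `COc1cc(OC)c(OC)cc1/C=C/C(=O)c1cc(O)ccc1O` gives > 150000 nM, and this too is a limit. Within the data shown here, compound 2 therefore stands at the limit of > 150000 nM in this assay, at which 2 of the 2 values shown sit, and the pair shows no measured step. Compound 3 `COc1cc(OC)c(OC)cc1/C=C/C(=O)c1ccc(Br)cc1` carries 4-bromophenyl in place of 2,5-dihydroxyphenyl on a carbonyl carbon. Only a modest move toward stronger inhibition is expected in this assay, an estimated at least 1.5-fold lower number from compound 2 to compound 3 (0.17 log units; that floor lies within the scatter). For compound 3 the expected value is 100000 nM, with an estimated range of 30000 nM to 200000 nM.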

Compound 3, half-maximal inhibitory concentration: 38200 nM
Compound 3: middle estimate off by 2.6-fold (0.42 log units), on the high side; the measured number falls inside the stated range.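

In this assay, the change on the carbonyl carbon produces the first readable shift: 4-bromophenyl in place of 2,5-dihydroxyphenyl gives an at least 3.9-fold lower number from compound 2 to compound 3 (0.59 log units; beyond the scatter). Bromo in place of 1H-imidazol-4-yl on an aromatic carbon likewise gives an at least 3.9-fold lower number from compound 1 to compound 3 (0.59 log units; beyond the scatter). Compound 1 and compound 2 remain at a limit of the assay, so both steps have only a floor: the limit of > 150000 nM in this assay, at which 2 of the 3 values shown sit.

Whether bromo itself matters remains open, since the compounds shown offer no comparison with chloro or methoxy on that aromatic carbon. From the compounds shown here alone, how an amine or a carboxylic acid there would read also remains open.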